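A few compounds are considered here, and "the series" means these few. Any claim that something is new, unique, unknown or untested is made for them only; others in the source may bear on it.

Compound 3 `CCc1ccc(-c2c(NS(=O)(=O)c3ccc(C(C)(C)C)cc3)ncnc2OCCOc2ncc(SC)cn2)cc1` gives 0.013 nM in an assay on cells (Endothelial cell) for binding affinity to Endothelin-1 receptor (Sus scrofa) (a lower number here means a stronger inhibitor, a higher number a weaker inhibitor), the lowest of the three numbers recorded there. Compound 2 `COc1cccc(Oc2c(NS(=O)(=O)c3ccc(C(C)(C)C)cc3)ncnc2OCCOc2nccc(C)n2)c1` gives 39.4 nM and compound 1 `COc1cccc(Oc2c(NS(=O)(=O)c3ccc(C(C)(C)C)cc3)ncnc2OCCOc2ccccc2)c1` gives 65 nM, so both stand far above compound 3 in this assay. Going by the values given here, the one measured step, a 1.6-fold lower number from compound 1 to compound 2 (0.22 log units; within the scatter), concerns a different part of the molecule and stays within the scatter. Compound 4 `CSc1cnc(OCCOc2ncnc(NS(=O)(=O)c3ccc(C(C)(C)C)cc3)c2-c2cccs2)nc1` differs from compound 3 by thiophen-2-yl in place of 4-ethylphenyl on an aromatic carbon. Among the compounds with values here, no measured step touches this position, so the size of the change cannot be read from the data; a modest weakening is expected. The step from compound 3 to compound 4 is expected to be a 6.2-fold higher number from compound 3 to compound 4 (0.79 log units; beyond the scatter). For compound 4 the estimated value is 0.08 nM, within 0.01 nM to 0.6 nM.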

Compound 4, half-maximal inhibitory concentration: 0.89 nM
Compound 4: middle estimate off by 11-fold (1.05 log units), on the low side, and the stated range ends below it.
By their numbers in this assay, from the lowest: compound 3; then compound 4; then compounds 2 and 1 (each within the scatter of the next).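

In this assay, thiophen-2-yl in place of 4-ethylphenyl gives a 68-fold higher number from compound 3 to compound 4 (1.84 log units; beyond the scatter) and so shows that the group on this aromatic carbon strongly affects the number. The change replaces a six-membered carbon ring of 8 heavy atoms with a five-membered sulfur-containing ring of 5 heavy atoms, and this single step cannot separate the ring from the ethyl group. No measurement explains the loss. The compounds shown leave open how a plain phenyl or a thiophen-3-yl on this carbon would compare with 4-ethylphenyl.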